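A Trifluoromethyl for a Methoxy on a Weak Series

This account rests on a few compounds, and the source may have more. Where it says the series, first, only, none or still open, it means among the compounds named here.

Compound 1, `O=C(Nc1ccc(Oc2ccnc3[nH]ccc23)c(F)c1)c1cc(-c2ccccc2)ccn1`: in a functional assay on MCF7 cells (Homo sapiens) for cytotoxicity, read by MTT assay, with a stated time of 72 h (a higher number here means a weaker inhibitor, a lower number a stronger inhibitor), compound 1 gives > 10000 nM, a limit of the assay.
Compound 2, `COc1ccc(-c2ccnc(C(=O)Nc3ccc(Oc4ccnc5[nH]ccc45)c(F)c3)c2)cc1`: in this assay compound 2 gives 9110 nM.

Going by the values given here, compound 2 carries the only true number here; the other value shown is a limit. Among the compounds with values here, the one measured step, an at least 1.0-fold lower number from compound 1 to compound 2 (0.04 log units; that floor lies within the scatter), runs from a limit to a number and stays within the scatter, so it gives no direction. Compound 3, `O=C(Nc1ccc(Oc2ccnc3[nH]ccc23)c(F)c1)c1cc(-c2ccc(C(F)(F)F)cc2)ccn1`, differs from compound 2 by trifluoromethyl in place of methoxy on an aromatic carbon. Within the data shown here, no measured step touches a trifluoromethyl at this carbon; what bears on the outlook is the limit of > 10000 nM in this assay, at which 1 of the 2 values shown sits, which shows how close these values sit to the edge of what this assay reports. Compound 3 is therefore expected to stay near compound 2, with a step of a 1.1-fold higher number from compound 2 to compound 3 (0.04 log units; within the scatter) that does not go beyond the scatter. Compound 3 is estimated at 10000 nM, in a range from 4000 nM to 30000 nM, with a real chance of a limit instead.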

Compound 3, half-maximal inhibitory concentration: 8550 nM
The estimate for compound 3 lay 1.2-fold (0.07 log units) above the measured number; low and high end bracket the measured number.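

On this aromatic carbon, para to a large group, the change from 4-methoxyphenyl to 4-(trifluoromethyl)phenyl gives a 1.1-fold lower number from compound 2 to compound 3 (0.03 log units; within the scatter), so the two groups cannot be told apart in this assay, even though methoxy has a hydrogen-bond acceptor and trifluoromethyl has none. The comparison with the unsubstituted phenyl gives an at least 1.1-fold lower number from compound 1 to compound 3 (0.06 log units; that floor lies within the scatter), but it starts from a limit and shows no direction for either group. Compound 3 therefore adds a second true number without moving the series away from the edge of what is reported: the limit of > 10000 nM in this assay, at which 1 of the 3 values shown sits.

The compounds shown leave open whether any group at this carbon, such as an amine or a carboxylic acid, would shift the number beyond the scatter. They also leave open whether a change in the shared core would do more than one at this carbon.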